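This account rests on a few compounds, and the source may have more. Where it says the series, first, only, none or still open, it means among the compounds named here.

Measured compounds:
compound 1, `CCCn1c(C)c(C(=O)O)c(-c2cccc(N3CCN(c4ccc(NS(=O)(=O)c5ccc(N[C@H](CCN6CCC(O)CC6)CSc6ccccc6)c(S(=O)(=O)C(F)(F)F)c5)cc4)CC3)c2)c1-c1ccc(Cl)cc1`: 7.5 nM
compound 2, `Cc1c(C(=O)NCCCN2CCN(C)CC2)c(-c2cccc(N3CCN(c4ccc(NS(=O)(=O)c5cccc(OC(C)C)c5)cc4)CC3)c2)c(-c2ccc(Cl)cc2)n1C`: 522 nM
compound 3, `CCOc1cccc(S(=O)(=O)Nc2ccc(N3CCN(c4cccc(-c5c(C(=O)NCCCN6CCN(C)CC6)c(C)n(C)c5-c5ccc(Cl)cc5)c4)CC3)cc2)c1`: 420 nM

In an assay for binding affinity to Apoptosis regulator Bcl-2 (Homo sapiens), read by fluorescence polarization, with a stated time of 2 h (on this read-out higher numbers stand for weaker inhibition and lower numbers for stronger inhibition), compound 3 stands second highest of these three numbers. Its nearest neighbour is compound 2: the step of a 1.2-fold lower number from compound 2 to compound 3 (0.09 log units; within the scatter) is small. Compound 1 lies far from it, with a much lower number beyond the scatter.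

Compound 4, `Cc1c(C(=O)NCCCN2CCN(C)CC2)c(-c2cccc(N3CCN(c4ccc(NS(=O)(=O)c5cccc(S(C)(=O)=O)c5)cc4)CC3)c2)c(-c2ccc(Cl)cc2)n1C`, differs from compound 3 by methylsulfonyl in place of ethoxy on an aromatic carbon. Among the measured compounds shown here, no measured step exchanges an ethoxy for a methylsulfonyl; the only step at hand, a 1.2-fold lower number from compound 2 to compound 3 (0.09 log units; within the scatter), touches the same ring but only trims the chain, and it was within the scatter. With nothing showing a sizeable effect at this position, the expected step of a 1.2-fold higher number from compound 3 to compound 4 (0.08 log units; within the scatter) is none beyond the scatter. Compound 4 is therefore estimated at 500 nM, in the range 150 nM to 1600 nM.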

Compound 4, inhibition constant: 658 nM
For compound 4 the middle estimate is 1.3-fold (0.12 log units) below the measured one; low and high end bracket the measured number.
By their numbers in this assay, from the lowest: compound 1; then compounds 3, 2 and 4 (each within the scatter of the next).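

In this assay, replacing an ether group with methylsulfonyl, a different kind of group with more heavy atoms and an extra hydrogen-bond acceptor, gives a 1.6-fold higher number from compound 3 to compound 4 (0.19 log units; within the scatter) and, starting from isopropoxy, a 1.3-fold higher number from compound 2 to compound 4 (0.10 log units; within the scatter). Both steps lie within the scatter, so this aromatic carbon has now carried three different groups with no measurable separation, whereas the earlier pair compared only two ether chains. No measurement available here explains why these groups read alike. Still open, as far as these compounds go, is whether an amine, a carboxylic acid or a longer chain at this carbon would shift the number beyond the scatter.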